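Notes on the cyclohexylmethyl analogue in this series

The compounds below may be only part of what the source reports. "The series", "measured", "known", "first", "only" and "open" are said of these compounds alone.

For the measured compounds named here, compound 1 `CN(C)CCN1CCN(c2nc(-c3ccccn3)nc3c2CN(Cc2ccc(F)cc2)CC3)CC1` and compound 2 `CN(C)CCN1CCN(c2nc(-c3ccccn3)nc3c2CN(Cc2ccsc2)CC3)CC1` share one core and differ only in the group on the saturated chain carbon bound to the amine nitrogen in a ring; no step between them is counted here, so only their two results are set side by side. In an assay on FRT cells with Cystic fibrosis transmembrane conductance regulator variant F508del (Homo sapiens) as the target, read by fluorescence, with a stated time of 25 min (a lower number here means a smaller maximal response, a higher number a larger maximal response), compound 1 gives "not active" (no number reported), reported without a number. In this assay compound 2 gives 79.8%, the only numerical result so far; compound 2 therefore stands as the single reference point, with compound 1 beside it without a figure. Compound 3 `CN(C)CCN1CCN(c2nc(-c3ccccn3)nc3c2CN(CC2CCCCC2)CC3)CC1` has not yet been run in this assay. It differs from compound 2 by cyclohexyl in place of thiophen-3-yl on a saturated chain carbon bound to an amine nitrogen in a ring. Going by the values given here, the only comparison at hand sets compound 1 at "not active" (no number reported) against compound 2 at 79.8%, which leaves the expected direction uncertain. A downward step beyond the scatter is nonetheless expected, about a number 29.8 percentage points lower from compound 2 to compound 3 (beyond the scatter). For compound 3 the estimate in this assay is 50%, with a range from 15% to 85%.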

Compound 3, largest response reached (Emax), in percent of the reference or control that the assay uses: 41%
Compound 3: the middle estimate sits 9 percentage points above what was measured; measured number inside the range.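

In this assay, the place on a saturated chain carbon bound to an amine nitrogen in a ring now has its first readable step, a number 38.8 percentage points lower from compound 2 to compound 3 (beyond the scatter), with cyclohexyl in place of thiophen-3-yl. An aromatic ring is not a condition for a numbered response at this place: compound 3, with a non-aromatic ring of carbon only, gives 41%, whereas compound 1, with its aromatic ring, gives "not active" (no number reported) in the same assay. Nothing at hand accounts for the size of this step.

On these data alone, whether an unsubstituted phenyl or a thiophen-2-yl at this place would read closer to compound 2 or to compound 3 stays open. An open-chain butyl or a piperidin-4-yl, which carries an amine, would show how far the response depends on a ring of carbon.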